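The source may report more compounds than this note shows. Statements on the series, on what has been measured and on what is new or still open speak of the compounds shown alone.

Three compounds of the series carry results in an ADME assay on L1210/0 cells (Mus musculus) for cytotoxicity, with a stated time of 48 h; on this read-out lower numbers stand for stronger inhibition and higher numbers for weaker inhibition. Compound 1 `OC[C@@H]1CCC[C@@H]1Cn1cnc2c(Cl)ncnc21` gives 52500 nM in this assay. Compound 3 `Nc1nc(Cl)c2nnn([C@H]3CCCC[C@H]3CO)c2n1` gives 95500 nM in this assay. For compound 2 `Nc1ncnc2c1ncn2C[C@@H]1C[C@H](O)c2ccccc21` the result in this assay is only a limit of the assay, > 200000 nM, and not a number. Compound 2 therefore stands at the limit of > 200000 nM in this assay, at which 1 of the 3 values shown sits. Of the three results shown, compound 2 is the one without a number, while compounds 1 and 3 each carry one. No two of these compounds differ in a single place, so no measured step is available from which a change could be sized.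

Compound 4 `Oc1ncnc2c1ncn2C[C@@H]1C[C@H](O)c2ccccc21` is not yet measured. It differs from compound 2 in one place: hydroxy in place of amino on an aromatic carbon. For the measured compounds named here, with compound 2 returning only a limit in this assay, and with no measured pair to draw on, the change cannot be read as going in either direction. The working expectation for compound 4 in this assay is a value of 250000 nM, estimated to lie within 90000 nM to 700000 nM. The step this estimate implies, a step that the limit leaves unreadable from compound 2 to compound 4, is expected to be none beyond the scatter, and it is likely that this assay again reports only a limit.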

Compound 4, half-maximal inhibitory concentration: > 200000 nM
Compound 4: no number, only a limit; the forecaster's own chance of this, stated with the estimate: 75%; the middle value lies beyond the limit too.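

Compound 2 and compound 4 both return only a limit in this assay, so no step can be read for hydroxy in place of amino on an aromatic carbon: the limit of > 200000 nM in this assay, at which 2 of the 4 values shown sit.

The compounds shown leave open whether this exchange changes the result in this assay at all, and how large any single change in the series would be.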